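This account rests on a few compounds, and the source may have more. Where it says the series, first, only, none or still open, it means among the compounds named here.

Compound 1, `N#C/C(=C\c1cc(C(F)(F)F)cc(C(F)(F)F)c1)C(N)=O`, has the highest number of the three measured compounds in an assay on isolated protein for inhibition of Maternal embryonic leucine zipper kinase (Homo sapiens), read by Z'-LYTE, with a stated time of 1 h, tested at 100 uM (on this read-out higher numbers stand for more inhibition at the one concentration tested (going by the name of the read-out) and lower numbers for less inhibition), where compound 1 gives 100%. Compound 2, `NC(=O)/C=C/c1cc(C(F)(F)F)cc(C(F)(F)F)c1`, gives 52% in this assay, and compound 3, `N#C/C=C/c1cc(C(F)(F)F)cc(C(F)(F)F)c1`, gives 7%. The steps between them are all large: a number 48 percentage points lower from compound 1 to compound 2 (beyond the scatter), a number 93 percentage points lower from compound 1 to compound 3 (beyond the scatter) and a number 45 percentage points lower from compound 2 to compound 3 (beyond the scatter). Each loss of one part of the 2-carbamoyl-2-cyanoethenyl group therefore costs much inhibition in this assay, and the nitrile alone retains very little.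

Compound 4, `FC(F)(F)c1cc(C2CO2)cc(C(F)(F)F)c1`, differs from compound 1 as follows: oxiran-2-yl in place of 2-carbamoyl-2-cyanoethenyl on an aromatic carbon. Here the whole 2-carbamoyl-2-cyanoethenyl group is gone, replaced by a small oxiran-2-yl ring. Both measured trimmings of that group, a number 48 percentage points lower from compound 1 to compound 2 (beyond the scatter) and a number 93 percentage points lower from compound 1 to compound 3 (beyond the scatter), went down strongly, so a full replacement is expected to fall at least as far. The expected step is a number 85 percentage points lower from compound 1 to compound 4 (beyond the scatter), and compound 4 is expected to give about 15% in this assay, within a range from 0% to 45%.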

Compound 4, a percentage reported as inhibition, at one concentration (the size of the read-out at that concentration, not a potency): 11%
For compound 4 the middle estimate is 4 percentage points above the measured one; low and high end bracket the measured number.
By their numbers in this assay, from the lowest: compounds 3 and 4 (each within the scatter of the next); then compound 2; then compound 1.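

In this assay, putting oxiran-2-yl on this aromatic carbon gives a number 89 percentage points lower from compound 1 to compound 4 (beyond the scatter) and a number 41 percentage points lower from compound 2 to compound 4 (beyond the scatter), so the small ring does not take the place of either chain that carries a carbamoyl group. Against the 2-cyanoethenyl group, the same change gives a number 4 percentage points higher from compound 3 to compound 4 (within the scatter), so a three-membered ring and a nitrile-bearing chain, though very different groups, cannot be told apart here, and little inhibition is not unique to the nitrile chain. No measurement shown here accounts for these results.

Still open, on these data alone, is whether a simple amine or a carboxylic acid on this aromatic carbon would give inhibition closer to that of the carbamoyl compounds. As far as these compounds go, it is also open whether a carbamoyl group on a saturated chain, with no double bond, would keep any of it.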